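A few compounds are considered here, and "the series" means these few. Any claim that something is new, unique, unknown or untested is made for them only; others in the source may bear on it.

Working notes on the series.

Two compounds have been run in an ADME assay on LLC-MK2 cells (Macaca mulatta) for cytotoxicity, read by spectrophotometry and crystal violet staining, with a stated time of 4 days (on this read-out lower numbers stand for higher toxicity in this test and higher numbers for lower toxicity in this test), so far. Compound 1, `CC(C)n1ncc2c(C(=O)Nc3cc(S(N)(=O)=O)ccc3F)cc(-c3cccs3)nc21`, gives 25000 nM. Compound 2, `CC(C)n1ncc2c(C(=O)Nc3cccc(F)c3F)cc(-c3cccs3)nc21`, gives 75000 nM, which is the higher of the two numbers; its nearest neighbour is compound 1, whose number is lower by a margin beyond the usual scatter, so compound 2 is the less toxic of the pair in this assay.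

The next compound is compound 3, `CC(C)n1ncc2c(C(=O)Nc3ccccc3S(N)(=O)=O)cc(-c3cccs3)nc21`. It differs from compound 2 in one place: 2-sulfamoylphenyl in place of 2,3-difluorophenyl on an amide-type nitrogen. Going by the values given here, no step between two measured compounds covers this change, so its size is not known from the data. Compound 1 also carries a sulfonamide group on the phenyl ring, and its lower number in this assay gives some pointer, but its substitution differs from that of compound 3, so the pointer is weak.

The expectation for compound 3 is a moderate move toward a lower number, a 1.9-fold lower number from compound 2 to compound 3 (0.27 log units; within the scatter), with the direction resting on compound 1 and its value 25000 nM. The estimate for compound 3 in this assay is 40000 nM, with a range from 15000 nM to 100000 nM.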

Compound 3, half-maximal cytotoxic concentration: 25000 nM
Estimate against measurement, compound 3: 1.6-fold (0.20 log units) above, within the range that was stated.
By their numbers in this assay, from the lowest: compounds 1 and 3 (each within the scatter of the next); then compound 2.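

Going by these compounds alone, the first single-change step at this position is a 3.0-fold lower number from compound 2 to compound 3 (0.48 log units; beyond the scatter), with 2-sulfamoylphenyl in place of 2,3-difluorophenyl on an amide-type nitrogen, read in this assay. Compound 1 gives 25000 nM and compound 3 gives 25000 nM, so these two compounds, which both carry a sulfamoyl group on the phenyl ring, are within the scatter of each other, while compound 2, without that group, has the highest number; none of the three compounds goes against this pattern, though three compounds make a narrow basis. No measurement is available that bears on the reason for this step.

The compounds shown leave open whether the step goes with the arrival of the sulfamoyl group or the departure of the two fluorines, as this change makes both at once. Also open, on these data alone, is where an unsubstituted phenyl, or a phenyl carrying an amine or a carboxylic acid, would stand at this position in this assay.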